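This account rests on a few compounds, and the source may have more. Where it says the series, first, only, none or still open, it means among the compounds named here.

Measured so far in an assay on HEK293 cells for displacement of a labelled ligand from Neuronal acetylcholine receptor; alpha4/beta2 (Homo sapiens); on this read-out higher numbers stand for weaker inhibition and lower numbers for stronger inhibition:
compound 1 `C/C=C\Oc1cncc(N2CCCNCC2)c1` gives 1.29 nM
compound 2 `COc1cncc(N2CCCNCCC2)c1` gives 1 nM

Compound 1 stands at the higher of the two numbers, but its nearest neighbour, compound 2, lies within the scatter of it, so the two values show no separation that can be read as a difference in this assay. Compound 3 `C=COc1cncc(N2CCCNCC2)c1` has not yet been measured. It differs from compound 1 in one place: vinyl in place of prop-1-en-1-yl on an oxygen on an aromatic ring. Among the compounds with values here, no pair of measured compounds shares this change, so nothing in the numbers at hand says how large a step it brings; the change only shortens the chain on the oxygen, and the expectation is a step of no more than the scatter, in no particular direction. Compound 3 is therefore expected at about 1.5 nM, with a range from 0.6 nM to 4 nM. The step this implies, a 1.2-fold higher number from compound 1 to compound 3 (0.07 log units; within the scatter), is expected to sit within the usual scatter, and a value outside the range would be the first sign that the chain length matters here.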

Compound 3, half-maximal inhibitory concentration: 5.01 nM
For compound 3 the middle estimate is 3.3-fold (0.52 log units) below the measured one; measured number above the stated range.
By their numbers in this assay, from the lowest: compounds 2 and 1 (each within the scatter of the next); then compound 3.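

In this assay, the group on the oxygen on the aromatic ring proves not to be a silent place: vinyl in place of prop-1-en-1-yl gives a 3.9-fold higher number from compound 1 to compound 3 (0.59 log units; beyond the scatter), and so the weaker inhibition of the pair belongs to the group with the shorter chain. Both groups carry 1 double bond outside aromatic rings, and neither has a ring, a hydrogen-bond donor, a hydrogen-bond acceptor or a net charge, so among the features counted here the pair differs only in heavy atoms, 3 carbon against 2 carbon, although this single pair cannot establish a trend with chain length. Nothing available here bears on why this change moves the number.

The compounds shown leave open whether a saturated group on the same oxygen, such as ethyl or propyl, or a longer chain, such as butyl, would extend this step, reverse it or leave the number unchanged. They also leave open whether vinyl and prop-1-en-1-yl would differ in the same direction on the core of compound 2.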